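Trifluoromethyl to methyl: from compound 3 to compound 4

This account rests on a few compounds, and the source may have more. Where it says the series, first, only, none or still open, it means among the compounds named here.

Values measured in a functional assay on A549 cells (Homo sapiens) for antiproliferative activity, read by MTT assay, with a stated time of 72 h (on this read-out lower numbers stand for stronger inhibition and higher numbers for weaker inhibition), are these:
- compound 1 `CCOc1ccc(-c2ccc3ncn(-c4cc(OC)c(OC)c(OC)c4)c3c2)cc1` (8550 nM)
- compound 2 `COc1cc(-n2cnc3ccc(-c4ccccc4Cl)cc32)cc(OC)c1OC` (> 10000 nM is a limit of the assay)
- compound 3 `COc1cc(-n2cnc3ccc(-c4ccc(C(F)(F)F)cc4)cc32)cc(OC)c1OC` (3390 nM)

Compound 3 stands lowest of the two exact numbers, and the remaining value is only a limit. Compound 4 `COc1cc(-n2cnc3ccc(-c4ccc(C)cc4)cc32)cc(OC)c1OC` carries methyl in place of trifluoromethyl on an aromatic carbon, para to a large group (methyl in place of trifluoromethyl on an aromatic carbon). The nearest guide is the modest change at this same place, a 2.5-fold lower number from compound 1 to compound 3 (0.40 log units; beyond the scatter) with trifluoromethyl in place of ethoxy. A second step, an at least 2.9-fold lower number from compound 2 to compound 3 (0.46 log units; beyond the scatter) with 4-(trifluoromethyl)phenyl in place of 2-chlorophenyl, starts from a limit. Neither step tests methyl directly, so only a small rise, not beyond the scatter, is expected in this assay overall. The expected step runs a 1.5-fold higher number from compound 3 to compound 4 (0.17 log units; within the scatter) by this estimate. For compound 4 the estimated value is 5000 nM within an expected range from 2000 nM to 11000 nM in all.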

Compound 4, half-maximal inhibitory concentration: 1940 nM
The estimate for compound 4 lay 2.6-fold (0.41 log units) above the measured number; measured number below the stated range.
By their numbers in this assay, from the lowest: compounds 4 and 3 (each within the scatter of the next); then compound 1. At a limit, above all of these: compound 2.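

In this assay, methyl in place of trifluoromethyl on this aromatic carbon, para to a large group, stays within the scatter (a 1.7-fold lower number from compound 3 to compound 4 (0.24 log units; within the scatter)). Methyl in place of ethoxy lies beyond it (a 4.4-fold lower number from compound 1 to compound 4 (0.64 log units; beyond the scatter)), so the gain seen earlier is not peculiar to trifluoromethyl. The step from 2-chlorophenyl gives only a floor (an at least 5.1-fold lower number from compound 2 to compound 4 (0.71 log units; beyond the scatter)), its starting value being a limit: (the limit of > 10000 nM in this assay, at which 1 of the 4 values shown sits).

From the compounds shown here alone, what an amine, a carboxylic acid or a propyl chain would give at this place stays open.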